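Furan-2-yl in Place of the Naphthyl Group

The compounds below may be only part of what the source reports. "The series", "measured", "known", "first", "only" and "open" are said of these compounds alone.

Measured in a functional assay on Ehrlich cells (Mus musculus) for antiproliferative activity, read by trypan blue exclusion, with a stated time of 2 h, tested at 25 ug/mL; a lower number here means a weaker effect, a higher number a stronger effect of the compound at the concentration tested:
compound 1 `N#CC1=C(N)N(c2ccc(S(N)(=O)=O)cc2)C2=C(C(=O)CCC2)C1c1ccccc1` gives 30%
compound 2 `N#CC1=C(N)N(c2ccc(S(N)(=O)=O)cc2)C2=C(C(=O)CCC2)C1c1ccc(O)cc1` gives 95%
compound 3 `COc1ccc(C2C(C#N)=C(N)N(c3ccc(S(N)(=O)=O)cc3)C3=C2C(=O)CCC3)c2ccccc12` gives 10%

Compound 3 stands lowest of the three numbers. Its nearest neighbour is compound 1, reached by the modest step of a number 20 percentage points lower from compound 1 to compound 3 (beyond the scatter); its furthest is compound 2, separated by the large step of a number 85 percentage points lower from compound 2 to compound 3 (beyond the scatter). Compound 4 `N#CC1=C(N)N(c2ccc(S(N)(=O)=O)cc2)C2=C(C(=O)CCC2)C1c1ccco1` differs from compound 3 by furan-2-yl in place of 4-methoxynaphthalen-1-yl on a saturated ring carbon. The two measured steps that alter this same group, a number 20 percentage points lower from compound 1 to compound 3 (beyond the scatter) and a number 85 percentage points lower from compound 2 to compound 3 (beyond the scatter), both changed the read-out well beyond the scatter, so a step of real size is expected, and since compound 3 is already at the bottom the room lies upward. Compound 4 is estimated at 30%, within 5% to 75%, an expected step of a number 20 percentage points higher from compound 3 to compound 4 (beyond the scatter).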

Compound 4, a percentage reported as activity, at one concentration (the size of the read-out at that concentration, not a potency): 0%
Compound 4: middle estimate off by 30 percentage points, on the high side; the measured number lies below the stated range.
By their numbers in this assay, from the lowest: compounds 4 and 3 (each within the scatter of the next); then compound 1; then compound 2.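

In this assay the step is a number 10 percentage points lower from compound 3 to compound 4 (within the scatter) so at this saturated ring carbon furan-2-yl and 4-methoxynaphthalen-1-yl cannot be told apart, despite their different ring systems. Plain phenyl does separate from furan-2-yl, as a number 30 percentage points lower from compound 1 to compound 4 (beyond the scatter) shows, and a number 95 percentage points lower from compound 2 to compound 4 (beyond the scatter) shows that furan-2-yl does not keep the high read-out of the 4-hydroxyphenyl group. No measurement here explains these differences. Going by these compounds, it remains open whether the hydroxy group is itself needed, or whether an amine or a carboxylic acid in its place on the phenyl ring would keep the read-out of compound 2.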